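A few compounds are considered here, and "the series" means these few. Any claim that something is new, unique, unknown or untested is made for them only; others in the source may bear on it.

Within the data shown here, compound 1 `CCc1cc(S(=O)(=O)N2C[C@H](c3ccccc3)NC2=O)ccc1NC(=O)c1ccc([N+](=O)[O-])cc1` is the one compound of this set with a measured number. Among the measured compounds shown here, in a functional assay on A549 cells (Homo sapiens) for cytotoxicity, read by MTT assay (a higher number here means a weaker inhibitor, a lower number a stronger inhibitor), compound 1 gives 700 nM, and that is the only value that stands as a number here. Compound 2 `Cc1cc(S(=O)(=O)N2C(=O)N[C@@H](c3ccccc3)C2C)ccc1NC(=O)c1ccc(N)cc1` reaches only the limit of the method, and in this assay compound 2 is recorded as > 10000 nM. That entry is a limit, not a number, a point noted as the limit of > 10000 nM in this assay, at which 1 of the 2 values shown sits.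

Compound 3 `CCCOC(=O)Nc1ccc(S(=O)(=O)N2C[C@H](c3ccccc3)NC2=O)cc1CC` is not yet measured. It keeps the shared core of compound 1 and changes only at the carbonyl carbon: propoxy in place of 4-nitrophenyl on a carbonyl carbon. For the measured compounds named here, no measured pair differing in this single place exists, so the size of the step can only be estimated from compound 1 and the structural change. The group that leaves is the larger one, and the propoxy that enters brings no aromatic ring; the expected direction in this assay is toward a weaker inhibitor, beyond the usual scatter, with an estimated step of a 4.3-fold higher number from compound 1 to compound 3 (0.63 log units; beyond the scatter). Compound 3 is therefore expected to give about 3000 nM in this assay, within a range from 800 nM to 10000 nM.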

Compound 3, half-maximal inhibitory concentration: 60 nM
Estimate against measurement, compound 3: 50-fold (1.70 log units) above; measured number below the stated range.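

The place on the carbonyl carbon, whose other neighbour is an amide-type nitrogen, proves highly sensitive to change in this assay: propoxy in place of 4-nitrophenyl gives a 12-fold lower number from compound 1 to compound 3 (1.07 log units; beyond the scatter), a large move toward a stronger inhibitor. The earlier compounds shown here offered no measured pair at this place, and this one shows that the 4-nitrophenyl group, with its aromatic ring, is not needed here for a low number, since the smaller propoxy, which has no ring, reads far better in this cell assay. Nothing measured in this set gives a reason for the size of this step.

The compounds shown leave open which part of the change carries the step, since the exchange removes the ring and the nitro group together and also brings in an oxygen on the carbonyl carbon. They also leave open how a plain phenyl, a shorter ethoxy, a longer butoxy or a propylamino group at the same carbonyl carbon would read in this assay, and so whether propoxy itself matters or whether simply losing 4-nitrophenyl is enough.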